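The source may hold more compounds than are shown below. What is called first, only, known or untested is meant among the compounds shown, and "the series" means these compounds.

Measured so far in a functional assay on U2OS cells with metabotropic glutamate receptor 5 (Homo sapiens) as the target, read by calcium flux; on this read-out lower numbers stand for smaller maximal responses and higher numbers for larger maximal responses:
Compound 1 `Fc1ccc(-c2nc(-c3ccc4c(c3)nnn4C3CCCC3)no2)cc1` gives 51%.
Compound 2 `CN1CCC(n2nnc3c2CCC(c2nc(-c4ccc(F)cc4)no2)C3)CC1` gives 91%.
Compound 3 `Fc1ccc(-c2noc(C3CCc4c(nnn4C4CCOC4)C3)n2)cc1` gives 96%.

Compound 3 and compound 2 lie within the scatter of each other, while compound 1 sits far beneath both, beyond the scatter. Compound 4 `CC(C)(C)Cn1nnc2c1CCC(c1nc(-c3ccc(F)cc3)no1)C2` is not yet measured; it differs from compound 3 as follows: neopentyl in place of oxolan-3-yl on an aromatic nitrogen. Within the data shown here, the only measured step at this same place is a number 5 percentage points higher from compound 2 to compound 3 (within the scatter), where one ring substituent on the aromatic nitrogen replaced another without a change beyond the scatter. On that basis the swap to neopentyl is expected to give a step of a number 6 percentage points lower from compound 3 to compound 4 (within the scatter), that is, nothing beyond the scatter. Compound 4 is therefore estimated at 90%, between 72% and 100%.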

Compound 4, largest response reached (reported as percent of maximum), in percent of the reference or control that the assay uses: 108%
Estimate against measurement, compound 4: 18 percentage points below; the measured number lies above the stated range.
By their numbers in this assay, from the lowest: compound 1; then compounds 2 and 3 (each within the scatter of the next); then compound 4.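

In this assay the swap to neopentyl gives a number 12 percentage points higher from compound 3 to compound 4 (beyond the scatter) and a number 17 percentage points higher from compound 2 to compound 4 (beyond the scatter) and thus shows that this place on the aromatic nitrogen does respond to its group, which the earlier exchange of one ring group for another did not show. Neopentyl differs from oxolan-3-yl both in having no ring and in having no oxygen, so these compounds cannot show which of the two differences matters. Nothing available explains the higher response. Still open, going by these compounds, is whether a carbon-only ring such as cyclohexyl or a longer chain such as n-hexyl would keep this higher response on the shared core.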